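A few compounds are considered here, and "the series" means these few. Any claim that something is new, unique, unknown or untested is made for them only; others in the source may bear on it.

Measured in a functional assay on KBVIN cells (Homo sapiens) for antiproliferative activity, read by sulforhodamine B assay, with a stated time of 3 days; a lower number here means that less compound is needed, a higher number that more compound is needed for the effect:
- compound 1 `CCC1=C(O)c2c(oc(-c3ccc(CC)cc3)cc2=O)C(CC)(CC)C1=O`: 0.07 uM
- compound 2 `CCC1=C(O)c2c(oc(-c3ccc(Br)cc3)cc2=O)C(CC)(CC)C1=O`: 15.7 uM

Compound 2, at 15.7 uM, has the higher of the two numbers. Compound 3 `CCC1=C(O)c2c(oc(-c3cccc(C)c3)cc2=O)C(CC)(CC)C1=O` differs from it as follows: 3-methylphenyl in place of 4-bromophenyl on an aromatic carbon, that is, 3-methylphenyl in place of 4-bromophenyl. Going by the values given here, one measured step bears on this: a 220-fold higher number from compound 1 to compound 2 (2.35 log units; beyond the scatter), a large step with bromo in place of ethyl on an aromatic carbon. Compound 3 loses the bromo but does not carry the ethyl, so only partial recovery is expected. The expected change in this assay is a 16-fold lower number from compound 2 to compound 3 (1.20 log units; beyond the scatter), towards a lower number. Compound 3 is estimated at 1 uM, within 0.1 uM to 8 uM.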

Compound 3, concentration for half-maximal effect: 3.69 uM
For compound 3 the middle estimate is 3.7-fold (0.57 log units) below the measured one, within the range that was stated.
By their numbers in this assay, from the lowest: compound 1; then compound 3; then compound 2.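

In this assay, 3-methylphenyl in place of 4-bromophenyl gives a 4.3-fold lower number from compound 2 to compound 3 (0.63 log units; beyond the scatter) at this aromatic carbon, so part of the loss seen with the bromo group is recovered. 3-Methylphenyl in place of 4-ethylphenyl gives a 53-fold higher number from compound 1 to compound 3 (1.72 log units; beyond the scatter) on the same carbon, so losing the bromo alone does not restore the low number of the ethyl compound. Nothing available here accounts for either step.

The step from 4-ethylphenyl to 3-methylphenyl changes the chain and its ring position together, leaving their shares unseparated. From the compounds shown here alone, how 4-methylphenyl, 4-propylphenyl or 4-methoxyphenyl would stand remains open.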